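The source may report more compounds than this note shows. Statements on the series, on what has been measured and on what is new or still open speak of the compounds shown alone.

Measured in an ADME assay on isolated protein for inhibition of sodium-dependent dopamine transporter (Homo sapiens), tested at 10 uM; a higher number here means more inhibition at the concentration tested (going by the name of the read-out), a lower number less inhibition:
compound 1 `O=C(NCCCCC(c1ccc(F)cc1)c1ccc(F)cc1)Nc1ccc(Cl)cc1` gives 82%
compound 2 `O=C(NCCCCC(c1ccc(F)cc1)c1ccc(F)cc1)Nc1ccc(I)cc1` gives 24%

Compound 2 stands lowest of the two numbers in this assay; the step of a number 58 percentage points lower from compound 1 to compound 2 (beyond the scatter) is the only one recorded, and it bears directly on the next change, since compound 3 `O=C(NCCCCC(c1ccc(F)cc1)c1ccc(F)cc1)Nc1ccc(Cl)c(C(F)(F)F)c1` returns to chloro. Change: 4-chloro-3-(trifluoromethyl)phenyl in place of 4-iodophenyl on an amide-type nitrogen. Among the measured compounds shown here, the trifluoromethyl has no precedent here, so the chloro-for-iodo reversal carries the expectation, though with wide uncertainty. Compound 3 is expected at 65% (range 35% to 90%), an estimated rise of a number 41 percentage points higher from compound 2 to compound 3 (beyond the scatter).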

Compound 3, a percentage reported as inhibition, at one concentration (the size of the read-out at that concentration, not a potency): 90%
Compound 3: the middle estimate sits 25 percentage points below what was measured; low and high end bracket the measured number.
By their numbers in this assay, from the lowest: compound 2; then compounds 1 and 3 (each within the scatter of the next).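

In this assay, 4-chloro-3-(trifluoromethyl)phenyl in place of 4-iodophenyl on an amide-type nitrogen gives a number 66 percentage points higher from compound 2 to compound 3 (beyond the scatter), so a larger aryl group, with 11 heavy atoms against 7, does not by itself bring the low number of compound 2. Trifluoromethyl in place of hydrogen on an aromatic carbon gives a number 8 percentage points higher from compound 1 to compound 3 (within the scatter), so with this addition and the chloro retained the number is level, and compound 1 and compound 3 cannot be told apart here. Nothing available explains the low number of compound 2.

Open: whether trifluoromethyl holds the number without the chloro, and whether bromo in place of chloro tracks compound 1 or compound 2.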